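Swapping the aryl group on the amine of compound 2

This account rests on a few compounds, and the source may have more. Where it says the series, first, only, none or still open, it means among the compounds named here.

Three related compounds have been tested in a functional assay on KB cells (Homo sapiens) for cytotoxicity, read by sulforhodamine B assay; a lower number here means a stronger inhibitor, a higher number a weaker inhibitor. Compound 1 `C=C1[C@@H](OC(C)=O)C[C@@H]2[C@](C)(CO[Si](C)(C)C(C)(C)C)[C@H](OC(C)=O)CC[C@@]2(C)[C@@H]1C[C@@H](Nc1ccccc1)C1=CCOC1=O` gives 5710 nM. Compound 2 `C=C1[C@@H](OC(C)=O)C[C@@H]2[C@](C)(CO[Si](C)(C)C(C)(C)C)[C@H](OC(C)=O)CC[C@@]2(C)[C@@H]1C[C@@H](Nc1ccccc1F)C1=CCOC1=O`, which carries a fluoro in place of a hydrogen on an aromatic carbon, gives 4740 nM. Compound 3 `C=C1[C@@H](OC(C)=O)C[C@@H]2[C@](C)(COC=O)[C@H](OC(C)=O)CC[C@@]2(C)[C@@H]1C[C@@H](Nc1ccc(Br)cc1)C1=CCOC1=O`, which differs in more than one place from the others, gives 24000 nM. Among these three numbers compound 2 has the lowest, though its gap to compound 1 is within the scatter, so the two cannot be ranked; only compound 3 sits clearly apart.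

The step now considered leads from compound 2 to compound 4 `C=C1[C@@H](OC(C)=O)C[C@@H]2[C@](C)(CO[Si](C)(C)C(C)(C)C)[C@H](OC(C)=O)CC[C@@]2(C)[C@@H]1C[C@@H](Nc1ccc(OC)cc1)C1=CCOC1=O`. The change is 4-methoxyphenyl in place of 2-fluorophenyl on an amine nitrogen. For the measured compounds named here, the only single-place step measured so far, a 1.2-fold lower number from compound 1 to compound 2 (0.08 log units; within the scatter), shows that a small alteration on this aromatic ring left the number essentially unmoved. Compound 3, with a 4-bromophenyl, differs at a second place as well, so its higher number cannot be attributed to the aryl group alone. Nothing in hand argues for a clear shift in this assay, so a step of a 1.2-fold higher number from compound 2 to compound 4 (0.06 log units; within the scatter) is expected, staying within the scatter.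

For compound 4 the estimate in this assay is 5500 nM, with a range from 2500 nM to 12000 nM.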

Compound 4, half-maximal inhibitory concentration: 5630 nM
For compound 4 the middle estimate is 1.0-fold (0.01 log units) below the measured one; the range from low to high includes it.
By their numbers in this assay, from the lowest: compounds 2, 4 and 1 (each within the scatter of the next); then compound 3.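

In this assay, 4-methoxyphenyl in place of 2-fluorophenyl on the amine nitrogen gives a 1.2-fold higher number from compound 2 to compound 4 (0.07 log units; within the scatter), and methoxy in place of hydrogen on the aromatic ring gives a 1.0-fold lower number from compound 1 to compound 4 (0.01 log units; within the scatter). The earlier step covered only a fluoro, whereas these two steps show that a methoxy, which brings an oxygen onto the ring, also leaves the number within the scatter, so phenyl, 2-fluorophenyl and 4-methoxyphenyl on this nitrogen cannot be told apart in this assay. No independent measurement is available to explain why these three numbers stay so close.

Compound 3 differs from the others at a second place as well, so what its 4-bromophenyl contributes on its own cannot be read from these compounds. Going by these compounds, it also remains open whether the number would stay put with a very different group on this nitrogen, such as a benzyl or cyclohexyl group, or with a carboxylic acid or a dimethylamino group on the aromatic ring.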